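Branching the hydroxyalkyl chain on a purine kinase inhibitor

This account rests on a few compounds, and the source may have more. Where it says the series, first, only, none or still open, it means among the compounds named here.

Compound 1 `CC(C)C[C@H](O)Nc1nc(Nc2ccc(-c3ncccn3)cc2)c2ncn(C(C)C)c2n1` carries a pyrimidinyl group on the aniline ring; in an assay on isolated protein (Asteroidea) for inhibition of G2/mitotic-specific cyclin-B (Asterina pectinifera), read by scintillation counting and 33P incorporation, with a stated time of 30 min (a lower number here means a stronger inhibitor, a higher number a weaker inhibitor), compound 1 gives "not determined" (no result reported). Going by the values given here, compound 2 `CCC[C@H](O)Nc1nc(Nc2ccc(-c3cncnc3)cc2)c2ncn(C(C)C)c2n1` is the only compound with a number: in this assay compound 2 gives 70 nM. Compound 3 `CC(C)C[C@H](O)Nc1nc(Nc2ccc(-c3cncnc3)cc2)c2ncn(C(C)C)c2n1` differs from compound 2 by methyl in place of hydrogen on a saturated chain carbon bound to two saturated chain carbons. Among the compounds with values here, no measured pair shows this change, so no step size is known. The step of a 1.1-fold lower number from compound 2 to compound 3 (0.03 log units; within the scatter) is expected to stay within the usual scatter, with no clear direction. Compound 3 is therefore expected to give about 65 nM, between 25 nM and 180 nM.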

Compound 3, half-maximal inhibitory concentration: 270 nM
For compound 3 the middle estimate is 4.2-fold (0.62 log units) below the measured one; the measured number lies above the stated range.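

In this assay, going by these compounds alone, this is the first reading of the chain position: going from propyl to isobutyl, with methyl in place of hydrogen on a saturated chain carbon bound to two saturated chain carbons, gives a 3.9-fold higher number from compound 2 to compound 3 (0.59 log units; beyond the scatter) and a weaker inhibitor. This position therefore responds to one added carbon, though only modestly. No evidence on hand accounts for the loss. From the compounds shown here alone, whether a longer chain or an amine at this place would fare better remains open. The step between compound 3 and compound 1 cannot be read.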